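Replacing a nitro-bearing ring with a methylphenyl group

A few compounds are considered here, and "the series" means these few. Any claim that something is new, unique, unknown or untested is made for them only; others in the source may bear on it.

Of the compounds shown here, three with a shared core have been measured in an assay on MDA-MB-231 cells for binding affinity to C-X-C chemokine receptor type 4 (Homo sapiens), read by immunofluorescence and microscopy, with stated times of 10 min and 30 min; a lower number here means that less compound is needed, a higher number that more compound is needed for the effect. Compound 1 `Cc1ccc(S(=O)(=O)NCc2ccc(CNC(=O)c3ccc([N+](=O)[O-])cc3)cc2)cc1` gives 10 nM. Compound 2 `COc1ccc(C(=O)NCc2ccc(CNS(=O)(=O)c3ccc(C)cc3)cc2)cc1` gives 100 nM, and compound 3 `COc1ccccc1C(=O)NCc1ccc(CNS(=O)(=O)c2ccccc2)cc1` gives 1 nM. Among these three numbers compound 1 stands second highest: its nearest neighbour is compound 2, and the furthest is compound 3, each separated from compound 1 by a step beyond the scatter. For the measured compounds named here, the only single-place step recorded, a 10-fold higher number from compound 1 to compound 2 (1.00 log units; beyond the scatter), comes from methoxy in place of nitro on an aromatic carbon.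

Compound 4 `Cc1ccc(S(=O)(=O)NCc2ccc(CNC(=O)c3cccc(C)c3)cc2)cc1` has not yet been measured. It differs from compound 1 by 3-methylphenyl in place of 4-nitrophenyl on a carbonyl carbon. Going by the values given here, the one step that bears on this change is a 10-fold higher number from compound 1 to compound 2 (1.00 log units; beyond the scatter), where the nitro group was exchanged and the number rose. Compound 4 likewise loses the nitro group, so a higher number in this assay is expected, although the entering 3-methylphenyl is not the methoxy group seen in compound 2, so the size remains uncertain. Compound 4 is therefore estimated to give 50 nM, within a range from 10 nM to 300 nM, corresponding to an expected step of a 5.0-fold higher number from compound 1 to compound 4 (0.70 log units; beyond the scatter).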

Compound 4, effective concentration (reported as EC, without a stated level of effect): 1000 nM
The estimate for compound 4 lay 20-fold (1.30 log units) below the measured number, and the stated range ends below it.
By their numbers in this assay, from the lowest: compound 3; then compound 1; then compound 2; then compound 4.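

Compound 1, compound 2 and compound 4 now form a set of three that differ only in the group on a carbonyl carbon whose other neighbour is the amide-type nitrogen, and in this assay this single place spans a wide range (a 100-fold higher number from compound 1 to compound 4 (2.00 log units; beyond the scatter)). The loss of the nitro group therefore does not settle the number on its own, since the two compounds without it also stand apart (a 10-fold higher number from compound 2 to compound 4 (1.00 log units; beyond the scatter)). Across the three, 4-nitrophenyl carries the lowest number, 4-methoxyphenyl the middle one and 3-methylphenyl the highest, but nothing at hand bears on why this order arises.

The step to compound 4 exchanges the substituent and the ring position in its group name together, so these compounds cannot show how much of the rise belongs to the methyl group and how much to its position, which 4-methylphenyl on the same carbonyl carbon would address. They also leave open how an amine or a carboxylic acid on this ring would compare with the nitro, methoxy and methyl groups.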